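The source may hold more compounds than are shown below. What is called first, only, known or untested is meant among the compounds shown, and "the series" means these compounds.

Measured so far:
compound 1, `Nc1scc(CN2CCN(c3ccc(Cl)cc3F)CC2)c1C(=O)c1ccc(Cl)cc1`: -81%
compound 2, `Nc1scc(CN2CCN(c3c(F)cccc3F)CC2)c1C(=O)c1cccc(C(F)(F)F)c1`: 4%

Compound 2 stands highest of the two numbers in a functional assay on CHO cells with adenosine receptor A1 (Homo sapiens) as the target, read by cAMP accumulation and immunoassay, with a stated time of 6 min, tested at 10 uM; a higher number here means a weaker effect of the compound at the concentration tested, a lower number a stronger effect; its nearest neighbour is compound 1, whose value lies lower by a gap beyond the scatter. Those two differ in more than one place, so their values alone cannot be split between the changes. Compound 3, `Nc1scc(CN2CCN(c3c(F)cccc3F)CC2)c1C(=O)c1ccc(Cl)cc1`, keeps the rest of compound 2 and carries 4-chlorophenyl in place of 3-(trifluoromethyl)phenyl on a carbonyl carbon. Compound 1 carries the same 4-chlorophenyl on its carbonyl carbon. On these data alone, a downward step of notable size in this assay is expected, though the share of this change in the gap from compound 2 to compound 1 is unknown. The step is estimated as a number 39 percentage points lower from compound 2 to compound 3 (beyond the scatter). For compound 3 the expected value is -35%, range -85% to 10%.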

Compound 3, a percentage reported as activity, at one concentration (the size of the read-out at that concentration, not a potency): -80%
The estimate for compound 3 lay 45 percentage points above the measured number, and the stated range covers the measured number.
By their numbers in this assay, from the lowest: compounds 1 and 3 (each within the scatter of the next); then compound 2.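

In this assay, for the compounds shown here, 4-chlorophenyl in place of 3-(trifluoromethyl)phenyl on the carbonyl carbon, as the only change, gives a number 84 percentage points lower from compound 2 to compound 3 (beyond the scatter), so this position alone can carry a large step. On the amine nitrogen in a ring, 2,6-difluorophenyl in place of 4-chloro-2-fluorophenyl gives a number 1 percentage points higher from compound 1 to compound 3 (within the scatter), so with 4-chlorophenyl on the carbonyl carbon these two groups are not told apart. Nothing on hand explains the large step. On these data alone, what 3-chlorophenyl or 4-(trifluoromethyl)phenyl on that carbonyl carbon would give remains open, so the identity of the substituent cannot yet be separated from its place on the ring.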